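Fluoro on the anilide ring: clearance in mouse microsomes

The compounds below may be only part of what the source reports. "The series", "measured", "known", "first", "only" and "open" are said of these compounds alone.

Compound 1 `CN1C[C@H](C(=O)Nc2ccccc2)[C@@H](c2ccc(/C=C/C(=O)Nc3ccccc3N)cc2)C1`: 67 mL/min/kg
Compound 2 `CN1C[C@H](C(=O)Nc2ccc(F)cc2)[C@@H](c2ccc(/C=C/C(=O)Nc3ccccc3N)cc2)C1`: 34 mL/min/kg
Compound 3 `COc1ccc(NC(=O)[C@H]2CN(C)C[C@@H]2c2ccc(/C=C/C(=O)Nc3ccccc3N)cc2)cc1`: 54 mL/min/kg

Three compounds share one core and differ only on the anilide ring. In an in vitro ADME assay on microsomes from liver (Mus musculus) for pharmacokinetics, read by LC-MS, with a stated time of 10 min, tested at 1 uM (on this read-out higher numbers stand for fast clearance and lower numbers for slow clearance), compound 1 gives the highest of the three numbers, though all three lie close together: the step of a 2.0-fold lower number from compound 1 to compound 2 (0.29 log units; within the scatter) and the step of a 1.2-fold lower number from compound 1 to compound 3 (0.09 log units; within the scatter) are both within the scatter, as is the step of a 1.6-fold higher number from compound 2 to compound 3 (0.20 log units; within the scatter).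

Compound 4 `CN1C[C@H](C(=O)Nc2cccc(F)c2)[C@@H](c2ccc(/C=C/C(=O)Nc3ccccc3N)cc2)C1` is the next member of this set. It differs from compound 1 by fluoro in place of hydrogen on an aromatic carbon. The step that bears most directly on it is a 2.0-fold lower number from compound 1 to compound 2 (0.29 log units; within the scatter), which places the same kind of change, fluoro in place of hydrogen on an aromatic carbon, on the same ring; it was a modest drop that stayed within the scatter. The methoxy step from compound 1 to compound 3 was smaller still. On this basis compound 4 is expected to sit near compound 1 and compound 2, with the step of a 1.5-fold lower number from compound 1 to compound 4 (0.17 log units; within the scatter) expected to stay within the scatter. The estimated value for compound 4 in this assay is 45 mL/min/kg, within a range of 25 mL/min/kg to 80 mL/min/kg.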

Compound 4, clearance: 56 mL/min/kg
The estimate for compound 4 lay 1.2-fold (0.09 log units) below the measured number; the measured number falls inside the stated range.
By their numbers in this assay, from the lowest: compounds 2, 3, 4 and 1 (each within the scatter of the next).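

In this assay, fluoro on the anilide ring has now been read at a second place: the 3-fluorophenyl group, with fluoro meta to a large group, gives a 1.2-fold lower number from compound 1 to compound 4 (0.08 log units; within the scatter) and stands against the other fluoro compound with a 1.6-fold higher number from compound 2 to compound 4 (0.22 log units; within the scatter). The place of the fluoro on this ring therefore makes no difference that can be told from the scatter. Against the methoxy compound the result is a 1.0-fold higher number from compound 3 to compound 4 (0.02 log units; within the scatter), so all four anilide rings shown remain within the scatter of one another, and none of these changes has yet separated the compounds in this assay.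

As far as these compounds go, it remains open whether an amine, a carboxylic acid or a longer chain on this ring would give a step beyond the scatter. No measurement shown accounts for these numbers.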